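This account rests on a few compounds, and the source may have more. Where it says the series, first, only, none or still open, it means among the compounds named here.

Working notes on the series.

Of the compounds shown here, three of a shared core have been measured in a functional assay on HepG2 cells (Homo sapiens) for cytotoxicity, read by MTT assay, with a stated time of 48 h; on this read-out lower numbers stand for stronger inhibition and higher numbers for weaker inhibition. Compound 1 `CCCCCCOc1ccc2c(NCCN(C)C)ccnc2c1` gives 1370 nM. Compound 2 `CN(C)CCNc1ccnc2cc(OCc3ccc(F)cc3)ccc12` gives 790 nM. Compound 3 `CCOc1ccc2c(NCCN(C)C)ccnc2c1` gives 5680 nM, the highest of the three numbers; its nearest neighbour is compound 1 and its furthest is compound 2, both steps beyond the scatter, so compound 3 is the weakest of those measured so far.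

Compound 4 `C=CCOc1ccc2c(NCCN(C)C)ccnc2c1` is not yet measured. It differs from compound 3 by vinyl in place of methyl on a saturated chain carbon bound to an oxygen on an aromatic ring, that is, ethoxy to allyloxy.

Going by the values given here, two measured steps bear on this. a 4.1-fold higher number from compound 1 to compound 3 (0.62 log units; beyond the scatter) and a 7.2-fold higher number from compound 2 to compound 3 (0.86 log units; beyond the scatter) both show that a smaller group at this position goes with a higher number, while a 1.7-fold lower number from compound 1 to compound 2 (0.24 log units; within the scatter) shows little difference between two larger groups. The change to compound 4 adds only one heavy atom and keeps the chain short, so a lower number than compound 3 in this assay is expected, but a smaller move than either of the steps to compound 3.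

Compound 4 is therefore estimated at 3500 nM in this assay, with a range of 1700 nM to 7000 nM, an expected step of a 1.6-fold lower number from compound 3 to compound 4 (0.21 log units; within the scatter).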

Compound 4, half-maximal inhibitory concentration: 1660 nM
Beside the measured number, compound 4's estimate is 2.1-fold (0.32 log units) above it; measured number below the stated range.
By their numbers in this assay, from the lowest: compounds 2, 1 and 4 (each within the scatter of the next, the first and the last beyond it); then compound 3.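

In this assay, the change from ethoxy to allyloxy alone moves the number beyond the scatter (a 3.4-fold lower number from compound 3 to compound 4 (0.53 log units; beyond the scatter)), so at this position a long chain or an added ring is not needed to leave the level of compound 3. Vinyl in place of pentyl stays within the scatter (a 1.2-fold higher number from compound 1 to compound 4 (0.08 log units; within the scatter)), so the allyloxy group of compound 4 cannot be told apart from the longer chain of compound 1, whereas vinyl in place of 4-fluorophenyl lies beyond the scatter (a 2.1-fold higher number from compound 2 to compound 4 (0.32 log units; beyond the scatter)), and compound 2 keeps the lower number. No measurement at hand accounts for the effect of vinyl in place of methyl at this position.

The compounds shown leave open whether the step to compound 4 goes with the double bond or with the added carbon alone, a question that a propyl group on the same oxygen would separate. They also leave open what an amine or a carboxylic acid carried on this chain would do to the number in this assay.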